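Hydrazone aryl variation in a splenocyte cytotoxicity series

The compounds below may be only part of what the source reports. "The series", "measured", "known", "first", "only" and "open" are said of these compounds alone.

Measured compounds:
compound 1, `O=C(CCN1CCN(c2ccnc3cc(Cl)ccc23)CC1)N/N=C/c1c[nH]c2ccccc12`, 5700 nM
compound 2, `O=C(CCN1CCN(c2ccnc3cc(Cl)ccc23)CC1)N/N=C/c1ccccc1Cl`, 10800 nM

Both compounds share one core and differ only in the aryl group on the carbon with a double bond to nitrogen. In an ADME assay on cells (Splenocyte, Mus musculus, strain BALB/c) for cytotoxicity, read by thymidine incorporation, with a stated time of 24 h (on this read-out higher numbers stand for weaker inhibition and lower numbers for stronger inhibition), compound 1 gives 5700 nM, and compound 2 gives 10800 nM. For the measured compounds named here, the single step between them, a 1.9-fold higher number from compound 1 to compound 2 (0.28 log units; within the scatter), lies within the scatter, so compound 2 stands as one of a pair whose two numbers cannot be told apart on this assay.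

Compound 3, `COc1cc(/C=N/NC(=O)CCN2CCN(c3ccnc4cc(Cl)ccc34)CC2)ccc1OC(C)=O`, carries the change (4-acetoxy-3-methoxyphenyl in place of 2-chlorophenyl on a carbon with a double bond to nitrogen). Going by the values given here, the only step that bears on this position is a 1.9-fold higher number from compound 1 to compound 2 (0.28 log units; within the scatter), which swapped the aryl group at the same place and produced nothing beyond the scatter. Among the compounds with values here, no measured step shows an aryl change at this position moving the number in this assay, and nothing here distinguishes the entering group from the groups already tried. The expected step, a 1.2-fold lower number from compound 2 to compound 3 (0.08 log units; within the scatter), is therefore estimated to remain within the scatter. Compound 3 is expected to give about 9000 nM in this assay, with a range from 3000 nM to 30000 nM.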

Compound 3, half-maximal inhibitory concentration: 15800 nM
Beside the measured number, compound 3's estimate is 1.8-fold (0.24 log units) below it; the measured number falls inside the stated range.
By their numbers in this assay, from the lowest: compounds 1, 2 and 3 (each within the scatter of the next, the first and the last beyond it).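

In this assay, for the compounds shown here, the aryl group on the carbon with a double bond to nitrogen now gives a first step beyond the scatter: 4-acetoxy-3-methoxyphenyl in place of 1H-indol-3-yl produces a 2.8-fold higher number from compound 1 to compound 3 (0.44 log units; beyond the scatter) and this shift is modest. The change from 2-chlorophenyl to the same entering group, with 12 heavy atoms in place of 7 and three hydrogen-bond acceptors in place of none, gives a 1.5-fold higher number from compound 2 to compound 3 (0.17 log units; within the scatter) and so does not separate these two groups. The position therefore responds only between the two ends of this short series, with compound 2 inseparable from either end, and no measurement on hand offers an explanation for that separation.

Open, from the compounds shown here alone, is whether the acetoxy group or the methoxy group of the entering aryl carries the step from the indolyl compound, or whether the two act only together. Also open, going by these compounds, is how this number would respond to an aryl group bearing an amine or a carboxylic acid at the same place, and whether such a group would extend the range seen so far in either direction.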